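This account rests on a few compounds, and the source may have more. Where it says the series, first, only, none or still open, it means among the compounds named here.

Measured so far:
- compound 1, `CC(C)(O)c1cncc(-n2ncc3ccccc32)c1`: 15 nM
- compound 2, `Cc1nn(-c2cncc(C(C)(C)O)c2)c2ccccc12`: 33.5 nM
- compound 3, `CC(C)(O)c1cncc(-n2ncc3cccc(F)c32)c1`: 0.9 nM

These three compounds were tested in an assay on cells for inhibition of cytochrome P450 11B2, mitochondrial (Homo sapiens), read by HTRF, with stated times of 1 h and 3 h; a higher number here means a weaker inhibitor, a lower number a stronger inhibitor. Compound 1 gives 15 nM, which places it second highest among the three numbers. The closest of the others is compound 2 at 33.5 nM, a step of a 2.2-fold higher number from compound 1 to compound 2 (0.35 log units; beyond the scatter), which came with a methyl in place of hydrogen on an aromatic carbon. The furthest is compound 3 at 0.9 nM, a step of a 17-fold lower number from compound 1 to compound 3 (1.22 log units; beyond the scatter), which came with a fluoro in place of hydrogen on an aromatic carbon.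

The compound now in question is compound 4, `CC(C)(O)c1cncc(-n2ncc3ccc(F)cc32)c1`. Its difference from compound 1 is fluoro in place of hydrogen on an aromatic carbon. Within the data shown here, the step that bears on it is the one from compound 1 to compound 3, since both involve a fluoro entering in place of hydrogen, though in compound 4 the fluoro sits at a different position on the same ring, so the size of that step cannot simply be carried over. Given the large lowering seen in a 17-fold lower number from compound 1 to compound 3 (1.22 log units; beyond the scatter), a lowering beyond the scatter in this assay is expected for compound 4, though probably of smaller size, an expected step of a 3.0-fold lower number from compound 1 to compound 4 (0.48 log units; beyond the scatter). The estimate for compound 4 is therefore 5 nM, with a range from 1.5 nM to 20 nM.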

Compound 4, half-maximal inhibitory concentration: 78.5 nM
The estimate for compound 4 lay 16-fold (1.20 log units) below the measured number, outside the stated range (above it).
By their numbers in this assay, from the lowest: compound 3; then compound 1; then compound 2; then compound 4.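

In this assay, the fluoro of compound 4, on an aromatic carbon meta to a fused ring and para to a fused ring, moves the number in the opposite direction from the fluoro of compound 3 (a 5.2-fold higher number from compound 1 to compound 4 (0.72 log units; beyond the scatter); by contrast, a 17-fold lower number from compound 1 to compound 3 (1.22 log units; beyond the scatter)). The same exchange of hydrogen for fluoro on the same ring of the shared core can therefore either raise or lower the number, so the direction of the change cannot be read from the group alone and depends on where it stands, at least across these two compounds. No measurement at hand accounts for this reversal.

What the compounds shown leave open is whether the rise belongs to fluoro specifically or to any group entering at this position, a question that a chloro, a methoxy or a nitrile on the same carbon would address. They also leave open how fluoro behaves on the other carbons of this ring, so the two fluoro positions seen here do not yet describe the ring as a whole.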